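Chloro in Place of Hydrogen: Compound 1 to Compound 3

The source may report more compounds than this note shows. Statements on the series, on what has been measured and on what is new or still open speak of the compounds shown alone.

Compound 1 `Cc1ccccc1Nc1nc(C)c(C(=O)/C=C/c2ccccc2)s1` is known in a functional assay on Bel-7402 cells (Homo sapiens) for cytotoxicity, read by MTT assay (on this read-out lower numbers stand for stronger inhibition and higher numbers for weaker inhibition), only by a limit: compound 1 gives > 25000 nM. Compound 2 `Cc1nc(Nc2ccccc2)sc1C(=O)/C=C/c1ccccc1` also sits at a limit, giving > 25000 nM in this assay. The step that the two limits leave unreadable from compound 1 to compound 2 is therefore unreadable, both values resting at the limit of > 25000 nM in this assay, at which 2 of the 2 values shown sit. Compound 3 `Cc1ccccc1Nc1nc(C)c(C(=O)/C=C/c2ccccc2Cl)s1` differs from compound 1 by chloro in place of hydrogen on an aromatic carbon, on an aromatic carbon of a six-membered aromatic ring of carbon only, ortho to a large group; one bond further out, phenyl to 2-chlorophenyl. Going by the values given here, no measured step bears on this change. Compound 3 is expected to stay near the limit, an estimated step that the limit leaves unreadable from compound 1 to compound 3. The estimate for compound 3 is 30000 nM, from 8000 nM to 100000 nM.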

Compound 3, half-maximal inhibitory concentration: > 25000 nM
Compound 3 was reported as a limit; the forecaster's own chance of this, stated with the estimate: 75%; the middle value is on the limit's open side.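

Compound 1 and compound 3 both rest at a limit, so no step can be read between them: the limit of > 25000 nM in this assay, at which 3 of the 3 values shown sit.

In this assay the compounds shown leave open how far each lies past the limit and what chloro in place of hydrogen changes.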